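Ester-side variation from compound 1 to compound 4

The compounds below may be only part of what the source reports. "The series", "measured", "known", "first", "only" and "open" are said of these compounds alone.

Measured so far:
compound 1, `O=C(OCCc1ccc(Cl)c(Cl)c1)N(c1ccccc1)C1CN2CCC1CC2`: 80 nM
compound 2, `O=C(OCc1ccccc1)N(c1ccccc1)C1CN2CCC1CC2`: 150 nM
compound 3, `O=C(OCCCc1ccccc1)N(c1ccccc1)C1CN2CCC1CC2`: 260 nM

In an assay on CHO cells for displacement of a labelled ligand from muscarinic acetylcholine receptor M5 (Homo sapiens), read by scintillation counting, with a stated time of 2 h (on this read-out higher numbers stand for weaker inhibition and lower numbers for stronger inhibition), compound 1 gives the lowest of the three numbers. Its nearest neighbour is reached by a 1.9-fold higher number from compound 1 to compound 2 (0.27 log units; within the scatter), the furthest by a 3.3-fold higher number from compound 1 to compound 3 (0.51 log units; beyond the scatter). Between the other two the step is a 1.7-fold higher number from compound 2 to compound 3 (0.24 log units; within the scatter). Among the compounds with values here, only the step to compound 3 lies beyond the scatter, so compound 1 and compound 2 cannot be ranked against each other.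

Compound 4, `COc1ccc(COC(=O)N(c2ccccc2)C2CN3CCC2CC3)cc1`, differs from compound 1 as follows: 4-methoxyphenyl in place of 3,4-dichlorobenzyl on a saturated chain carbon bound to an oxygen next to a carbonyl group. Within the data shown here, the step that bears on this is the one from compound 1 to compound 2, which also removes the 3,4-dichlorobenzyl in favour of an unsubstituted ring on the same saturated chain carbon and gave a 1.9-fold higher number from compound 1 to compound 2 (0.27 log units; within the scatter), a small rise within the scatter. Among the measured compounds shown here, no measured compound carries a 4-methoxyphenyl, so the contribution of that group is not covered by the data. The expectation for compound 4 is therefore a step of similar size to that seen on going to compound 2, a 1.9-fold higher number from compound 1 to compound 4 (0.27 log units; within the scatter), upward or possibly none beyond the scatter. Compound 4 is estimated at 150 nM, with a range from 60 nM to 400 nM.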

Compound 4, inhibition constant: 470 nM
For compound 4 the middle estimate is 3.1-fold (0.50 log units) below the measured one, and the stated range ends below it.
By their numbers in this assay, from the lowest: compounds 1, 2, 3 and 4 (each within the scatter of the next, the first and the last beyond it).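

Within the data shown here, only the step to compound 4 from compound 2 holds the chain fixed and changes the ring alone: with methoxy in place of hydrogen on an aromatic carbon, this assay gives a 3.1-fold higher number from compound 2 to compound 4 (0.50 log units; beyond the scatter), so this ring substitution is not neutral at this position. With 4-methoxyphenyl in place of 3,4-dichlorobenzyl, the series shows a 5.9-fold higher number from compound 1 to compound 4 (0.77 log units; beyond the scatter), which lies beyond the scatter, whereas the step from the dichloro compound to the unsubstituted ring of compound 2 stayed within it, so the ring pattern at this position can be read in the numbers. Against the phenethyl group of compound 3 the result is a 1.8-fold higher number from compound 3 to compound 4 (0.26 log units; within the scatter), which lies within the scatter, so compound 3 and compound 4 cannot be ranked against each other.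

No accompanying data bear on why the methoxy group shifts the number in this way. Still open, as far as these compounds go, is how a single chlorine, a hydroxyl or a dimethylamino group on the same ring would read, and whether methoxy on the two-carbon chain of compound 1 would give a step of comparable size.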